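The compounds below may be only part of what the source reports. "The series", "measured", "known", "first", "only" and "open" are said of these compounds alone.

Measured compounds in a functional assay on PC-3 cells (Homo sapiens) for cytotoxicity, read by MTT assay, with a stated time of 72 h; a lower number here means a stronger inhibitor, a higher number a weaker inhibitor:

- compound 1 (`COc1cc(-c2cncc(N[C@@H](C)c3ccccc3)n2)ccc1O`): 10000 nM
- compound 2 (`CCCC(=O)Nc1ccc(-c2cncc(NC(CCC)c3cccnc3)n2)cc1OC`): 600 nM
- compound 3 (`CCC[C@H](Nc1ccnc(-c2ccc(NC(=O)NCC)c(OC)c2)n1)c1cccnc1`): 150 nM

Compound 3 has the lowest of the three numbers. Its nearest neighbour is compound 2, whose number is higher by a margin beyond the scatter; compound 1 lies much further off, also beyond the scatter. The three compounds differ in several places at once, so none of these gaps can be tied to a single structural change.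

Compound 4 (`CCC[C@H](Nc1cc(C)nc(-c2ccc(NC(=O)NCC)c(OC)c2)n1)c1cccnc1`) is the next compound in the series. It differs from compound 3 only in this: methyl in place of hydrogen on an aromatic carbon. Among the measured compounds shown here, no pair among the measured compounds isolates a change of this kind, so there is no measured step to lean on. A single methyl on the core is expected to move the number little, most likely staying within the scatter of compound 3, with a modest shift in either direction possible. Compound 4 is therefore estimated at 150 nM, with a range from 50 nM to 500 nM. The expected step is no change at the digits printed from compound 3 to compound 4 (within the scatter).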

Compound 4, half-maximal inhibitory concentration: 200 nM
The estimate for compound 4 lay 1.3-fold (0.12 log units) below the measured number; the range from low to high includes it.
By their numbers in this assay, from the lowest: compounds 3 and 4 (each within the scatter of the next); then compound 2; then compound 1.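

Methyl in place of hydrogen on an aromatic carbon gives a 1.3-fold higher number from compound 3 to compound 4 (0.12 log units; within the scatter) in this assay and so provides the first single-place step in the series. Among the compounds shown here, this position, next to the ring nitrogen and meta to two large groups, therefore accepts a methyl without a shift beyond the scatter, which the earlier compounds, differing in several places at once, could not show. No supporting data are available to explain this result.

From the compounds shown here alone, whether the position tolerates more than a methyl remains open: an ethyl, a longer chain, a methoxy, a chlorine or an amine at this carbon could give a different result. This single step also leaves open whether a methyl at other aromatic carbons of the shared core would behave the same way.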